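The compounds below may be only part of what the source reports. "The series", "measured", "known", "first", "only" and "open" are said of these compounds alone.

Three compounds built on one shared core have been run in an ADME assay on Vero cells (Chlorocebus sabaeus) for cytotoxicity, read by resazurin assay, with a stated time of 3 days; on this read-out higher numbers stand for weaker inhibition and lower numbers for stronger inhibition. Compound 1 `CCCOCC(=O)Nc1cc2nc(C3CCCCC3)[nH]c2cc1N(CC)CC` reaches only the limit of the assay: in this assay compound 1 gives > 100 ug/mL, a limit rather than a number. Compound 2 `CCCNC(=O)Nc1cc2nc(C3CCCCC3)[nH]c2cc1N(CC)CC` likewise returns a limit, with > 100 ug/mL in this assay. Compound 3 `CCN(CC)c1cc2[nH]c(C3CCCCC3)nc2cc1NC(=O)c1ccc(C)cc1` also stops at a limit in this assay, > 100 ug/mL. All three values sit at the limit of > 100 ug/mL in this assay, at which 3 of the 3 values shown sit, so compound 3 stands alongside its companions with no number of its own. The steps a step that the two limits leave unreadable from compound 1 to compound 2, a step that the two limits leave unreadable from compound 1 to compound 3 and a step that the two limits leave unreadable from compound 2 to compound 3 are consequently of unreadable size. Compound 4 `CCN(CC)c1cc2[nH]c(C3CCCCC3)nc2cc1NC(=O)c1ccc(Br)cc1` has not yet been measured; it differs from compound 3 by bromo in place of methyl on an aromatic carbon. Going by the values given here, none of the measured steps concerns this change, and all three are hidden by the limits, so no step beyond the scatter is expected in this assay. Compound 4 is accordingly estimated to give 100 ug/mL in this assay, within a range of 50 ug/mL to 200 ug/mL. The step of a number no higher from compound 3 to compound 4 (the limit leaves the size open) that this estimate implies is expected to be nil, with a further limit the most likely outcome.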

Compound 4, half-maximal inhibitory concentration: > 100 ug/mL
Compound 4 ended at the assay's limit (the forecaster's own chance of this, stated with the estimate: 85%); the middle value sits exactly at the limit.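

In this assay compound 4 gives the limit > 100 ug/mL and not a number. Its steps from compound 1, compound 2 and compound 3 therefore cannot be read: the limit of > 100 ug/mL in this assay, at which 4 of the 4 values shown sit. The compounds shown leave open how far these four lie from one another in this assay.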